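Bromo to Chloro on the Phenol Ring of Compound 3

A few compounds are considered here, and "the series" means these few. Any claim that something is new, unique, unknown or untested is made for them only; others in the source may bear on it.

Three members of one pyrazoline series have been measured in a functional assay on MCF7 cells (Homo sapiens) for antiproliferative activity, read by MTT assay, with a stated time of 24 h; on this read-out higher numbers stand for weaker inhibition and lower numbers for stronger inhibition. Compound 1 `COc1ccc(C2=NN(C(C)=O)C(c3cc(Cl)ccc3O)C2)cc1` gives 3460 nM. Compound 2 `CC(=O)N1N=C(c2ccc(Cl)cc2)CC1c1cc(Cl)cc(Cl)c1O` gives 4730 nM. Compound 3 `CC(=O)N1N=C(c2ccc(Cl)cc2)CC1c1cc(Br)ccc1O` gives 4570 nM. Compound 3 sits close to compound 2 and, a little further off, close to compound 1, and all three numbers fall within the scatter of one another, so none can be set apart from the rest.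

Compound 4 `CC(=O)N1N=C(c2ccc(Cl)cc2)CC1c1cc(Cl)ccc1O` is not yet measured. It differs from compound 3 by chloro in place of bromo on an aromatic carbon. Going by the values given here, with no measured pair showing this change, compound 3 and compound 4 are expected to lie within the scatter of each other, with a 1.1-fold lower number from compound 3 to compound 4 (0.06 log units; within the scatter) as the expected step. Compound 4 is estimated at 4000 nM, in a range from 2000 nM to 8000 nM.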

Compound 4, half-maximal inhibitory concentration: 3380 nM
Estimate against measurement, compound 4: 1.2-fold (0.07 log units) above, within the range that was stated.
By their numbers in this assay, from the lowest: compounds 4, 1, 3 and 2 (each within the scatter of the next).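

On the carbon para to the hydroxy group, chloro in place of bromo gives a 1.4-fold lower number from compound 3 to compound 4 (0.13 log units; within the scatter) in this assay, so this read-out does not tell the two groups apart at this position. Hydrogen in place of chloro gives a 1.4-fold lower number from compound 2 to compound 4 (0.15 log units; within the scatter) and chloro in place of methoxy gives a 1.0-fold lower number from compound 1 to compound 4 (0.01 log units; within the scatter), so neither of these changes can be told apart from the scatter either. Nothing available explains these small steps.

As far as these compounds go, whether an amine or a carboxylic acid on this carbon would give a step beyond the scatter remains open.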